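Carboxy side chain in place of hydroxypiperidinylmethyl on the core

A few compounds are considered here, and "the series" means these few. Any claim that something is new, unique, unknown or untested is made for them only; others in the source may bear on it.

Compound 1 `Cn1ncc(Cl)c1-c1cc(C(=O)N[C@@H]2CN[C@H](CCN3CCC(O)CC3)C[C@H]2c2ccc(Cl)c(Cl)c2)oc1Cl`: 15900 nM
Compound 2 `Cn1ncc(Cl)c1-c1cc(C(=O)N[C@@H]2CNCC[C@H]2c2ccc(C(F)(F)F)cc2)oc1Cl`: 120 nM

In a functional assay on OVCAR-8 cells (Homo sapiens) for antiproliferative activity (on this read-out lower numbers stand for stronger inhibition and higher numbers for weaker inhibition), compound 1 gives 15900 nM, the higher of the two numbers recorded; compound 2 gives 120 nM, a difference beyond the scatter. Compound 3 `Cn1ncc(Cl)c1-c1cc(C(=O)N[C@@H]2CN[C@H](CC(=O)O)C[C@H]2c2ccc(Cl)c(Cl)c2)oc1Cl` keeps the core and the dichlorophenyl group of compound 1 but carries carboxy in place of (4-hydroxypiperidin-1-yl)methyl on a saturated chain carbon bound to a saturated ring carbon. Within the data shown here, no measured pair shows this change directly, so any expectation rests on compound 1 alone. A modest move toward a lower number, close to the scatter, is expected from compound 1 to compound 3 a 2.0-fold lower number from compound 1 to compound 3 (0.30 log units; within the scatter). Compound 3 is therefore estimated at 8000 nM, within 1500 nM to 40000 nM.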

Compound 3, half-maximal inhibitory concentration: 5120 nM
Compound 3: middle estimate off by 1.6-fold (0.19 log units), on the high side; low and high end bracket the measured number.
By their numbers in this assay, from the lowest: compound 2; then compound 3; then compound 1.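

In this assay, carboxy in place of (4-hydroxypiperidin-1-yl)methyl gives a 3.1-fold lower number from compound 1 to compound 3 (0.49 log units; beyond the scatter) with the dichlorophenyl group kept. This place, a saturated chain carbon bound to a saturated ring carbon, thus takes a group with no ring in place of one with a six-membered ring, and the number does not rise. No measured evidence bears on why the number moved. Still open, as far as these compounds go, is whether a primary amine or a methyl ester in place of carboxy would shift the number further, and whether the step holds with other aryl groups.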